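The source may report more compounds than this note shows. Statements on the series, on what has been measured and on what is new or still open speak of the compounds shown alone.

In an assay on HEK293 cells for positive allosteric modulation of metabotropic glutamate receptor 2 (Rattus norvegicus), read by thallium flux, with a stated time of 2.5 min (a lower number here means a smaller maximal response, a higher number a larger maximal response), compound 2 `Cc1c(OCCCCOc2ccc(C(=O)O)cc2F)ccc(C(=O)CC(C)C)c1O` gives 85%. Within the data shown here, compound 1 `Cc1cc(C(=O)O)ccc1OCCCCOc1ccc(C(=O)CC(C)C)c(O)c1C` gives 83.9%, and the only measured step, a number 1.1 percentage points higher from compound 1 to compound 2 (within the scatter), lies within the scatter, so the two compounds cannot be ranked against each other. Compound 3 `COC(=O)c1ccc(OCCCCOc2ccc(C(=O)CC(C)C)c(O)c2C)cc1` is not yet measured; it differs from compound 2 by 4-(methoxycarbonyl)phenyl in place of 4-carboxy-2-fluorophenyl on an oxygen on a saturated carbon. Among the measured compounds shown here, no measured step touches this part of the molecule, so nothing in the data points to a shift beyond the scatter, and the expected step of a number 1 percentage points lower from compound 2 to compound 3 (within the scatter) is small. Compound 3 is therefore estimated at 84%, with a range from 70% to 96%.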

Compound 3, largest response reached (reported as percent of maximum), in percent of the reference or control that the assay uses: 16.4%
The estimate for compound 3 lay 67.6 percentage points above the measured number; the whole stated range lies above it.
By their numbers in this assay, from the lowest: compound 3; then compounds 1 and 2 (each within the scatter of the next).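

In this assay, the group on this oxygen turns out to matter greatly, with a number 68.6 percentage points lower from compound 2 to compound 3 (beyond the scatter) and a number 67.5 percentage points lower from compound 1 to compound 3 (beyond the scatter), whereas exchanging fluoro for methyl had shown nothing beyond the scatter. The new group differs in two ways: methoxycarbonyl stands in place of carboxy, and the ring carries neither fluoro nor methyl. The compounds shown leave open which of these two differences matters, and a plain 4-carboxyphenyl group on the same oxygen would separate them. No measurement available here explains the loss of response.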